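The source may hold more compounds than are shown below. What is called first, only, known or untested is meant among the compounds shown, and "the series" means these compounds.

In a functional assay on RAW264.7 cells (Mus musculus), read by immunoassay, with a stated time of 24 h (a higher number here means a weaker inhibitor, a lower number a stronger inhibitor), compound 2 `O=C(Oc1ccc(Oc2ccccc2)cc1)N(Nc1ccccc1)S(=O)(=O)c1ccc(-c2ccccc2)cc1` gives 161 nM, within the scatter of compound 3 `O=C(Oc1ccc(OCc2ccccc2)cc1)N(Nc1ccccc1)S(=O)(=O)c1ccc(-c2ccccc2)cc1` at 93 nM, while compound 1 `COc1ccccc1OC(=O)N(Nc1ccccc1)S(=O)(=O)c1ccc(C)cc1` shows a clearly lower number at 34.1 nM. Compound 4 `Cc1cc(C)c(S(=O)(=O)N(Nc2ccccc2)C(=O)Oc2ccc(Oc3ccccc3)cc2)c(C)c1` differs from compound 2 in one place, on a sulfonyl sulfur: 2,4,6-trimethylphenyl in place of 4-phenylphenyl on a sulfonyl sulfur, with 2,4,6-trimethylphenyl in place of 4-phenylphenyl. Among the measured compounds shown here, the only measured single-place step, a 1.7-fold lower number from compound 2 to compound 3 (0.24 log units; within the scatter), swaps a different group and stays within the scatter, so it bears only indirectly on this change. For the measured compounds named here, no measured step isolates the group on the sulfonyl sulfur, so no direction can be claimed. The expected result is no shift beyond the scatter, an estimated 1.3-fold lower number from compound 2 to compound 4 (0.13 log units; within the scatter). For compound 4 the estimate is 120 nM, with an expected range from 40 nM to 350 nM.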

Compound 4, half-maximal inhibitory concentration: 177 nM
For compound 4 the middle estimate is 1.5-fold (0.17 log units) below the measured one, within the range that was stated.
By their numbers in this assay, from the lowest: compound 1; then compounds 3, 2 and 4 (each within the scatter of the next).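

In this assay, putting 2,4,6-trimethylphenyl in place of 4-phenylphenyl on a sulfonyl sulfur gives a 1.1-fold higher number from compound 2 to compound 4 (0.04 log units; within the scatter). Among the compounds shown here, this is the first step that isolates this position, and it shows that two aromatic rings of carbon can give way to one while the two numbers stay within the scatter of each other. No measured evidence here explains this result.

Only these two carbon-only aromatic groups can be compared directly at this position. On these data alone, a group carrying an amine or a carboxylic acid, or a plain alkyl chain on the sulfonyl sulfur, remains open.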